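The source may hold more compounds than are shown below. What is called first, only, known or untested is meant among the compounds shown, and "the series" means these compounds.

Compound 1 `CC1=C(/C=C/C(=O)/C=C/c2cccc(C(F)(F)F)c2)C(C)(C)CCC1O` gives 3500 nM in a functional assay on PC-3 cells (Homo sapiens) for cytotoxicity, read by MTT assay, with a stated time of 72 h; on this read-out lower numbers stand for stronger inhibition and higher numbers for weaker inhibition. Compound 2 `CC1=C(/C=C/C(=O)/C=C/c2cc(C(F)(F)F)ccc2C(F)(F)F)C(C)(C)CCC1O` gives 1900 nM in this assay. The change from compound 1 to compound 2 is trifluoromethyl in place of hydrogen on an aromatic carbon, and it gave a 1.8-fold lower number from compound 1 to compound 2 (0.27 log units; within the scatter). Compound 3 `CC1=C(/C=C/C(=O)/C=C/c2ccccc2F)C(C)(C)CCC1O` gives 10400 nM in this assay, the highest of the three numbers; the values of compound 1 and compound 2 both lie beyond the scatter below it. The difference between the core of compound 3 and the core of compound 1 is not broken down here.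

Compound 4 `CC1=C(/C=C/C(=O)/C=C/c2c(F)cccc2C(F)(F)F)C(C)(C)CCC1O` is not yet measured. It differs from compound 3 by trifluoromethyl in place of hydrogen on an aromatic carbon. This is the same kind of change as that from compound 1 to compound 2, though the surroundings differ: the entering group stands ortho to a large group and para to a trifluoromethyl group in compound 2, but ortho to a large group and meta to a fluoro group in compound 4. Going by the values given here, the step from compound 3 to compound 4 is expected to be a 1.8-fold lower number from compound 3 to compound 4 (0.25 log units; within the scatter), resting on the single observed step of a 1.8-fold lower number from compound 1 to compound 2 (0.27 log units; within the scatter), which lies within the scatter. Compound 4 is therefore expected to give about 5800 nM in this assay, between 2900 nM and 11600 nM.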

Compound 4, half-maximal inhibitory concentration: 8800 nM
Estimate against measurement, compound 4: 1.5-fold (0.18 log units) below, within the range that was stated.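

In this assay, trifluoromethyl in place of hydrogen on an aromatic carbon gave a 1.2-fold lower number from compound 3 to compound 4 (0.07 log units; within the scatter), so both steps for this change now lie within the scatter. The two steps also do not differ from each other beyond the scatter, and on these two cores the change carries over without a detectable difference in size: the same change on two cores in this assay, a 1.8-fold lower number (0.27 log units; within the scatter) from compound 1 to compound 2 and a 1.2-fold lower number (0.07 log units; within the scatter) from compound 3 to compound 4, 1.6-fold (0.19 log units) apart, within the scatter of two such steps. This does not show that the change has a real effect of its own on either core, and one step on each of two cores says nothing about how it would behave on other cores or in other surroundings.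

The aromatic substituents shown are limited to fluoro and trifluoromethyl, so the outcome with an amine, a methoxy group or a carboxylic acid on the aromatic ring remains open. Also open, on these data alone, is whether replacing the hydroxyl group common to all four compounds, for instance with an ether, would move the number beyond the scatter.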